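Solubility notes on a piperidine amide series

This account rests on a few compounds, and the source may have more. Where it says the series, first, only, none or still open, it means among the compounds named here.

Measured so far:
compound 1 `Cc1oc(-c2ccccc2Cl)nc1CN1CCC(C(=O)NCCCN2C[C@H](C)C[C@H](C)C2)CC1`, > 72 ug/mL
compound 2 `Cc1ccccc1-c1nc(CN2CCC(C(=O)NCCCN3CC4CCCC(C4)C3)CC2)c(C)o1`, > 71 ug/mL

In a physicochemical assay for solubility, in phosphate buffer, measured as kinetic solubility, at pH 7.4 (on this read-out lower numbers stand for lower solubility and higher numbers for higher solubility), compound 1 gives > 72 ug/mL, which is a limit of the assay and not a number. Compound 2 also reaches a limit in this assay, > 71 ug/mL. Both results stop at the limit (the limit of > 72 ug/mL in this assay, at which 1 of the 2 values shown sits, (the limit of > 71 ug/mL in this assay, at which 1 of the 2 values shown sits)), so neither compound can be placed above the other. Compound 3 `COc1cccc(F)c1-c1nc(CN2CCC(C(=O)NCCCN3C[C@H](C)C[C@H](C)C3)CC2)c(C)o1` is not yet measured; it carries 2-fluoro-6-methoxyphenyl in place of 2-chlorophenyl on an aromatic carbon. Among the measured compounds shown here, no step between measured compounds is known, so for compound 3 no shift beyond the scatter is expected in this assay. The expected step of an at least 1.0-fold lower number from compound 1 to compound 3 (0.01 log units; that floor lies within the scatter) is therefore small. Compound 3 is expected to give 70 ug/mL in this assay, between 30 ug/mL and 120 ug/mL.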

Compound 3, solubility: > 74 ug/mL
Compound 3: only a limit was reported; the forecaster's own chance of this, stated with the estimate: 55%; at least 1.0-fold (0.02 log units) between middle value and limit.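

In this assay, among the compounds shown here, compound 1 and compound 3 both stop at a limit, so no step between them can be read. The compounds shown leave open whether 2-fluoro-6-methoxyphenyl in place of 2-chlorophenyl changes the result at all.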